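Swapping one cyclic amino acid group for another

This account rests on a few compounds, and the source may have more. Where it says the series, first, only, none or still open, it means among the compounds named here.

Compound 1 `COc1ccc(/C=C\c2cc(OC)c(OC)c(OC)c2)cc1OCc1ccc(CNC(C)(C)C(=O)O)cc1`: 6500 nM
Compound 2 `COc1ccc(/C=C\c2cc(OC)c(OC)c(OC)c2)cc1OCc1ccc(C=O)cc1`: 800 nM
Compound 3 `COc1ccc(/C=C\c2cc(OC)c(OC)c(OC)c2)cc1OCc1ccc(CN2C[C@H](O)C[C@@H]2C(=O)O)cc1`: > 10000 nM (a limit of the assay)

All three results come from a functional assay on HepG2 cells (Homo sapiens) for antiproliferative activity, read by CCK-8 assay, with a stated time of 48 h; on this read-out lower numbers stand for stronger inhibition and higher numbers for weaker inhibition. Compound 3 gives only a limit, > 10000 nM, and not an exact number.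

Compound 4 `COc1ccc(/C=C\c2cc(OC)c(OC)c(OC)c2)cc1OCc1ccc(CN2CCCC[C@H]2C(=O)O)cc1` keeps the core of compound 3 and changes one group: 2-carboxypiperidin-1-yl in place of 2-carboxy-4-hydroxypyrrolidin-1-yl on a saturated chain carbon bound to an aromatic carbon. In words, 2-carboxypiperidin-1-yl stands in place of 2-carboxy-4-hydroxypyrrolidin-1-yl on a saturated chain carbon bound to an aromatic carbon.

Among the compounds with values here, no measured step makes this exact swap. The closest one also exchanges one carboxy-bearing amine group for another: an at least 1.5-fold higher number from compound 1 to compound 3 (0.18 log units; that floor lies within the scatter). The two larger steps involve formyl, a group without the carboxy function, so they describe a different kind of change: an 8.1-fold lower number from compound 1 to compound 2 (0.91 log units; beyond the scatter) and an at least 12-fold higher number from compound 2 to compound 3 (1.09 log units; beyond the scatter).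

The closest step therefore carries the most weight, and no clear move beyond the scatter is expected in this assay. Compound 4 is expected to remain in the weak range of compound 1, at 6500 nM. Compound 4 may again reach only a limit. The expected step is an at least 1.1-fold lower number from compound 3 to compound 4 (0.04 log units; that floor lies within the scatter). For compound 4 the estimated value is 9000 nM, with an expected range from 3500 nM to 25000 nM.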

Compound 4, half-maximal inhibitory concentration: > 10000 nM
Compound 4 gave a limit, no number; the forecaster's own chance of this, stated with the estimate: 45%; middle value at least 1.1-fold (0.04 log units) away from the limit.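

Swapping 2-carboxy-4-hydroxypyrrolidin-1-yl for 2-carboxypiperidin-1-yl does not bring back measurable activity in this assay, so a six-membered ring without the hydroxy group joins the five-membered ring with it at the limit of the assay. Formyl gives way to (2-carboxypiperidin-1-yl)methyl in an at least 12-fold higher number from compound 2 to compound 4 (1.09 log units; beyond the scatter), which shows that a second carboxy-bearing ring amine also falls far short of the formyl compound. Against the open-chain group of compound 1, the change gives an at least 1.5-fold higher number from compound 1 to compound 4 (0.18 log units; that floor lies within the scatter), and as that floor lies within the scatter, no order can be stated for this pair.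

The step between the two ring compounds cannot be read, because both results are limits and not numbers: the limit of > 10000 nM in this assay, at which 2 of the 4 values shown sit.

Every amine shown here carries a carboxylic acid, so the amine and the acid cannot be judged apart. On these data alone, how a plain piperidin-1-yl group, or a methyl ester in place of the carboxylic acid, would read in this assay remains open.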